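Acetyl to (1-aminopropyl)carbonyl on compound 1

A few compounds are considered here, and "the series" means these few. Any claim that something is new, unique, unknown or untested is made for them only; others in the source may bear on it.

Among the compounds with values here, in a functional assay on U-87MG ATCC cells (Homo sapiens) for antiproliferative activity (on this read-out higher numbers stand for weaker inhibition and lower numbers for stronger inhibition), compound 1 (`CC(=O)N1CCc2c(C)c3c(n2-c2ccc(C(N)=O)c(c2)N[C@@H](C)[C@H](C)C1)CC(C)(C)CC3=O`) gives 24 nM as the lower of the two numbers measured so far. Compound 2 (`COCCC(=O)N1CCCc2c(C)c3c(n2-c2ccc(C(N)=O)c(c2)N[C@@H](C)[C@@H]1C)CC(C)(C)CC3=O`) gives 80 nM as the other number, higher than that of compound 1 by more than the scatter.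

Compound 3 (`CC[C@H](N)C(=O)N1CCc2c(C)c3c(n2-c2ccc(C(N)=O)c(c2)N[C@@H](C)[C@H](C)C1)CC(C)(C)CC3=O`) keeps the core of compound 1 and carries one change (1-aminopropyl in place of methyl on a carbonyl carbon): 1-aminopropyl in place of methyl on a carbonyl carbon whose other neighbour is an amide-type nitrogen in a ring. Cut one bond further out, the same difference reads acetyl to (1-aminopropyl)carbonyl.

Within the data shown here, no step between measured compounds that differ in one place is available, so the data give no direct precedent for this change and what follows is expectation only. In this assay the expected step (a 1.3-fold higher number from compound 1 to compound 3 (0.10 log units; within the scatter)) is a slight rise in the number that stays within the scatter. The expected upper end is set with compound 2 at 80 nM in view. For compound 3 the estimate is 30 nM as the expected value, with 10 nM to 90 nM as the expected range.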

Compound 3, half-maximal inhibitory concentration: 45 nM
Compound 3: the middle estimate sits 1.5-fold (0.18 log units) below what was measured; measured number inside the range.
By their numbers in this assay, from the lowest: compounds 1, 3 and 2 (each within the scatter of the next, the first and the last beyond it).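

In this assay the exchange of methyl for 1-aminopropyl on a carbonyl carbon whose other neighbour is an amide-type nitrogen in a ring gives a 1.9-fold higher number from compound 1 to compound 3 (0.27 log units; within the scatter) and so leaves the two compounds unseparated. Within the data shown here, this is the first direct reading at this position: a group of 4 heavy atoms, with a hydrogen-bond donor, a hydrogen-bond acceptor and a defined stereocentre, replaces a single methyl carbon on the core of compound 1 without a difference beyond the scatter. No measurement at hand accounts for this result, so it stands as an observation on one pair of compounds only.

The compounds shown leave open whether the other configuration at the new stereocentre of the 1-aminopropyl group would read the same, and whether the primary amine matters at all, which a plain propyl chain on the same carbonyl carbon would test. A longer chain carrying the amine, a dimethylamino group or a carboxylic acid at this place would show how far the position extends.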